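Swapping the Anilide Ring in a Cytotoxicity Series

A few compounds are considered here, and "the series" means these few. Any claim that something is new, unique, unknown or untested is made for them only; others in the source may bear on it.

Measured compounds:
- compound 1, `Nc1nn(Cc2cn(-c3ccc(O)c([N+](=O)[O-])c3)nn2)c2nc(-c3ccccc3)cc(C(F)(F)F)c12`: 41.3 ug/mL
- compound 2, `Cc1c(Br)cccc1-n1cc(Cn2nc(N)c3c(C(F)(F)F)cc(-c4ccccc4)nc32)nn1`: 97.2 ug/mL
- compound 3, `Nc1nn(Cc2cn(CC(=O)Nc3cccc(F)c3)nn2)c2nc(-c3ccccc3)cc(C(F)(F)F)c12`: 43.5 ug/mL

All three share one core and differ only in the group on an aromatic nitrogen. In a functional assay on U-937 cells (Homo sapiens) for cytotoxicity, read by MTT assay, with a stated time of 24 h (on this read-out higher numbers stand for weaker inhibition and lower numbers for stronger inhibition), compound 3 sits second highest of the three numbers; its nearest neighbour is compound 1, with a 1.1-fold higher number from compound 1 to compound 3 (0.02 log units; within the scatter), and its furthest is compound 2, with a 2.2-fold lower number from compound 2 to compound 3 (0.35 log units; beyond the scatter).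

Compound 4, `Nc1nn(Cc2cn(CC(=O)Nc3ccc(F)cc3Br)nn2)c2nc(-c3ccccc3)cc(C(F)(F)F)c12`, keeps the whole of compound 3 except for one change on the amide-type nitrogen: 2-bromo-4-fluorophenyl in place of 3-fluorophenyl on an amide-type nitrogen.

For the measured compounds named here, no measured step touches this amide-type nitrogen, so none bears directly on the change. The steps that exist, a 2.4-fold higher number from compound 1 to compound 2 (0.37 log units; beyond the scatter) and a 2.2-fold lower number from compound 2 to compound 3 (0.35 log units; beyond the scatter), move a bromine-bearing ring on and off the aromatic nitrogen, a different place, and both are only modest. With no closer guide, compound 4 is expected to stay close to compound 3, and the estimated step is a 1.1-fold higher number from compound 3 to compound 4 (0.06 log units; within the scatter), which would lie within the scatter. The estimated value for compound 4 in this assay is therefore 50 ug/mL, with a plausible range from 25 ug/mL to 100 ug/mL.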

Compound 4, half-maximal inhibitory concentration: 98.3 ug/mL
Compound 4: middle estimate off by 2.0-fold (0.29 log units), on the low side; the measured number falls inside the stated range.
By their numbers in this assay, from the lowest: compounds 1 and 3 (each within the scatter of the next); then compounds 2 and 4 (each within the scatter of the next).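

For the compounds shown here, this is the first measured change on the amide-type nitrogen, and in this assay there is a 2.3-fold higher number from compound 3 to compound 4 (0.35 log units; beyond the scatter) when 2-bromo-4-fluorophenyl takes the place of 3-fluorophenyl, so the ring on this nitrogen does affect the read-out, if only modestly. The same higher range can now be reached from two different places on the molecule: a 1.0-fold higher number from compound 2 to compound 4 (0.00 log units; within the scatter) leaves these two compounds indistinguishable although they differ on the aromatic nitrogen, while a 2.4-fold higher number from compound 1 to compound 4 (0.38 log units; beyond the scatter) is a modest step of about the same size as the one from the fluorophenyl anilide. No measurement available here says why the number moved.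

The entering ring differs from the leaving one both by its added bromine and by where its fluorine stands, so the compounds shown cannot separate these two differences. Also open, from the compounds shown here alone, is what would happen with an amine or a carboxylic acid on this ring in place of the bromine, or with a longer chain in place of the methyl link in the ((3-fluorophenyl)carbamoyl)methyl group.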